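Notes on an N-substituent change in the bromoaryl imidazoline series

The source may report more compounds than this note shows. Statements on the series, on what has been measured and on what is new or still open speak of the compounds shown alone.

Measured compounds, with the result in a physicochemical assay for acid dissociation:
compound 1 `Brc1ccc(N(CC2CC2)C2=NCCN2)c(Br)c1` gives 11.2
compound 2 `CCCCN(C1=NCCN1)c1c(Br)cccc1Br` gives 11
compound 3 `CC(C)CCN(C1=NCCN1)c1c(Br)cccc1Br` gives 10.9

Compound 2 gives the second highest of the three numbers. Its nearest neighbour is compound 3, which sits a number 0.10 log units lower from compound 2 to compound 3 (within the scatter); its furthest is compound 1, and the gap between compound 2 and compound 1 is also within the scatter. The three measured numbers therefore cannot be put in any order.

The next compound, compound 4 `C=C(C)CN(C1=NCCN1)c1c(Br)cccc1Br`, differs from compound 2 in one place: 1-methylethenyl in place of propyl on a saturated chain carbon bound to a nitrogen on an aromatic ring. Among the measured compounds shown here, of the measured steps, only the one from compound 2 to compound 3 alters the same chain, and it reads a number 0.10 log units lower from compound 2 to compound 3 (within the scatter). For the measured compounds named here, no measured step introduces a double bond outside aromatic rings, so there is nothing to read from that part of the change. On the evidence of the chain step alone, the change from compound 2 to compound 4 is expected to give no movement in this assay beyond the scatter, with the step of a number 0.10 log units lower from compound 2 to compound 4 (within the scatter) estimated for it.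

For compound 4 the expected value in this assay is 10.9, with a range from 10.4 to 11.3.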

Compound 4, acid dissociation constant: 10.7
For compound 4 the middle estimate is 0.20 log units above the measured one; the measured number falls inside the stated range.
By their numbers in this assay, from the lowest: compounds 4, 3, 2 and 1 (each within the scatter of the next, the first and the last beyond it).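

In this assay, among the compounds shown here, this is the first step at the saturated chain carbon bound to a nitrogen on an aromatic ring that brings in a double bond outside aromatic rings, and with 1-methylethenyl in place of propyl it reads a number 0.30 log units lower from compound 2 to compound 4 (within the scatter). With 1-methylethenyl in place of isobutyl at the same carbon, the reading is a number 0.20 log units lower from compound 3 to compound 4 (within the scatter), so neither comparison separates the chain carrying the double bond from the saturated chains, and the position has so far shown no step that stands clear of the scatter. No supporting measurement is available to account for either step.

Going by these compounds, it remains open whether any group at this carbon can move the number beyond the scatter, for instance a chain ending in an amine or a carboxylic acid, a longer chain, or a phenyl ring. Compound 1 differs from the other compounds in more than one place, so its chain cannot be read against theirs, and the contribution of the double bond cannot be separated from the change in chain shape that accompanies it.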